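This account rests on a few compounds, and the source may have more. Where it says the series, first, only, none or still open, it means among the compounds named here.

The measure throughout is an in vitro assay on V79MZ cells for inhibition of cytochrome P450 11B1, mitochondrial (Homo sapiens); a lower number here means a stronger inhibitor, a higher number a weaker inhibitor. Compound 1 `Cc1c(C)c(C)c(Cn2cnc3ccccc32)c(C)c1C` returns only a limit in this assay, > 1000 nM. Compound 3 `c1ccc(C(CCn2cnc3ccccc32)(c2ccccc2)c2ccccc2)cc1` likewise returns only a limit in this assay, > 1000 nM. Among the measured compounds shown here, compound 2 `c1ccc(-c2cc(Cn3ccnc3)cc(-c3ccccc3)c2)cc1` is the single compound with an actual number: in this assay compound 2 gives 128 nM. For the measured compounds named here, two of the three recorded values rest at the limit of > 1000 nM in this assay, at which 2 of the 3 values shown sit, so compound 2 stands alone as the only quantified inhibitor among them, and no pair of measured compounds differs in just one place to show how any single change shifts potency.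

Compound 4 `c1ccc(-c2cccc(Cn3ccnc3)c2)cc1` differs from compound 2 by hydrogen in place of phenyl on an aromatic carbon. Going by the values given here, with no measured step to calibrate the change, the expectation rests on compound 2 alone and on the removal of a phenyl group. Compound 4 is expected to be a somewhat weaker inhibitor than compound 2, the expected step of a 3.1-fold higher number from compound 2 to compound 4 (0.49 log units; beyond the scatter) lying beyond the usual scatter. Compound 4 is estimated at 400 nM in this assay, with a range from 150 nM to 1200 nM.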

Compound 4, half-maximal inhibitory concentration: 46 nM
The estimate for compound 4 lay 8.7-fold (0.94 log units) above the measured number; the measured number lies below the stated range.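

Replacing phenyl with hydrogen on this aromatic carbon, meta to a (1H-imidazol-1-yl)methyl group and meta to a phenyl group, gives a 2.8-fold lower number from compound 2 to compound 4 (0.44 log units; beyond the scatter) in this assay. Among the compounds shown here, this is the first single change that can be read, and it shows that the phenyl group at this position is not needed for inhibition: compound 4, which keeps only the other phenyl group, is the stronger inhibitor of the pair. Nothing measured here accounts for the size or direction of this step.

The compounds shown leave open whether a small group on this carbon, such as methyl, fluorine or methoxy, would match hydrogen or move the number further. They also leave open how an amine or a carboxylic acid would fare at the same position.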